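Chloro Added to the Methylphenyl Amide

The compounds below may be only part of what the source reports. "The series", "measured", "known", "first", "only" and "open" are said of these compounds alone.

Compound 2 `Cc1cccc(C(=O)NCN2CCC(c3cccc[n+]3[O-])CC2)c1` gives 89 nM in a functional assay on HEK293 cells for agonist activity at D(4) dopamine receptor (Homo sapiens), read by FLIPR (a lower number here means that less compound is needed, a higher number that more compound is needed for the effect), the lowest of the two numbers seen so far; compound 1 `O=C(NCN1CCC(c2cccc[n+]2[O-])CC1)c1ccccc1` gives 532 nM. Compound 3 `Cc1cc(C(=O)NCN2CCC(c3cccc[n+]3[O-])CC2)ccc1Cl` differs from compound 2 by chloro in place of hydrogen on an aromatic carbon. Going by the values given here, no measured step introduces a chloro; the only step available, a 6.0-fold lower number from compound 1 to compound 2 (0.78 log units; beyond the scatter), shows that a single small group on this ring can move the number, but it is an imperfect guide. The change expected is therefore modest and possibly within the scatter: a 1.8-fold lower number from compound 2 to compound 3 (0.25 log units; within the scatter). Compound 3 is estimated at 50 nM, within 15 nM to 180 nM.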

Compound 3, half-maximal effective concentration: 2460 nM
For compound 3 the middle estimate is 49-fold (1.69 log units) below the measured one, outside the stated range (above it).
By their numbers in this assay, from the lowest: compound 2; then compound 1; then compound 3.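

In this assay chloro on this aromatic carbon, ortho to a methyl group, gives a 28-fold higher number from compound 2 to compound 3 (1.44 log units; beyond the scatter) and so runs opposite to the earlier methyl step, a 6.0-fold lower number from compound 1 to compound 2 (0.78 log units; beyond the scatter), showing that a small group on this ring can push the number either way. With both groups in place the gain is lost, as 4-chloro-3-methylphenyl in place of phenyl gives a 4.6-fold higher number from compound 1 to compound 3 (0.67 log units; beyond the scatter). No measurement shown here accounts for this rise. The compounds shown leave open whether the rise belongs to chloro itself or to any group on this carbon, such as fluoro or methoxy. They also leave open whether chloro would act the same way without the methyl group.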